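A few compounds are considered here, and "the series" means these few. Any claim that something is new, unique, unknown or untested is made for them only; others in the source may bear on it.

The measured compounds in a functional assay on the whole organism (blood, strain Wistar-Okamoto) with Rattus norvegicus as the target, with a stated time of 5 days; a lower number here means that less compound is needed, a higher number that more compound is needed for the effect:
Compound 1, `CC(C)CC/N=C(\NC#N)Nc1cccnc1`, gives 20 mg/kg.
Compound 2, `CCC(C)(C)/N=C(\NC#N)Nc1ccncc1`, gives 2.5 mg/kg.
Compound 3, `CCC(C)(C)N/C(=N\C(N)=O)Nc1cccnc1`, gives > 50 mg/kg, which is a limit of the assay and not a number.

Compound 1 and compound 2 both carry a nitrile on the guanidine and both return a measured dose, with compound 2 at the lower one. As far as these compounds go, compound 3 carries a carbamoyl in that position and stands at the limit of > 50 mg/kg in this assay, at which 1 of the 3 values shown sits, so the assay reports no number for it; where it truly lies beyond that limit is unknown.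

Compound 4, `CCC(C)(C)N/C(=N\c1ncccn1)Nc1cccnc1`, is the next compound to be tested and differs from compound 3 in one place: pyrimidin-2-yl in place of carbamoyl on a double-bonded nitrogen. Within the data shown here, since compound 3 is known only as a limit, there is no measured step that guides this change, and the outcome rests on expectation alone. A step downward in dose, beyond the usual scatter, is expected: an at least 2.5-fold lower number from compound 3 to compound 4 (0.39 log units; beyond the scatter). Compound 4 is estimated to need 20 mg/kg, with a range from 5 mg/kg to 50 mg/kg.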

Compound 4, minimum effective dose: > 35 mg/kg
Compound 4 ended at the assay's limit; the forecaster's own chance of this, stated with the estimate: 35%; middle value at least 1.7-fold (0.24 log units) from the limit.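

Among these compounds, compound 3 and compound 4 are both known in this assay only as limits of the assay, and no step between them can be read. The compounds shown leave open whether pyrimidin-2-yl or carbamoyl on a double-bonded nitrogen calls for the lower dose.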